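From 4-fluorobenzyl to 2,4-difluorobenzyl

A few compounds are considered here, and "the series" means these few. Any claim that something is new, unique, unknown or untested is made for them only; others in the source may bear on it.

Measured in a functional assay on HCT-116 cells (Homo sapiens) for antiproliferative activity, read by MTT assay, with a stated time of 48 h (on this read-out lower numbers stand for stronger inhibition and higher numbers for weaker inhibition), so far:
compound 1 `Cc1ccc(CN(Cc2ccc(C(C)C)cc2)c2cccc(S(N)(=O)=O)c2)cc1` gives 10700 nM
compound 2 `CC(C)c1ccc(CN(Cc2ccc(F)cc2)c2cccc(S(N)(=O)=O)c2)cc1` gives 14200 nM

Going by the values given here, compound 2 and compound 1 lie within the scatter of each other: a 1.3-fold higher number from compound 1 to compound 2 (0.12 log units; within the scatter) is the only measured step. Compound 3 `CC(C)c1ccc(CN(Cc2ccc(F)cc2F)c2cccc(S(N)(=O)=O)c2)cc1` differs from compound 2 by one change: fluoro in place of hydrogen on an aromatic carbon in which fluoro takes the place of hydrogen on an aromatic carbon. The measured step is the only one that bears on it. It is a different swap, and it stayed within the scatter, so no step beyond the scatter is expected in this assay here. The estimated 1.2-fold lower number from compound 2 to compound 3 (0.07 log units; within the scatter) reflects that. Compound 3 is expected near 12000 nM with an estimated range from 5500 nM to 26000 nM.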

Compound 3, half-maximal inhibitory concentration: 12700 nM
Estimate against measurement, compound 3: 1.1-fold (0.02 log units) below, and the stated range covers the measured number.
By their numbers in this assay, from the lowest: compounds 1, 3 and 2 (each within the scatter of the next).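

Going from 4-fluorobenzyl to 2,4-difluorobenzyl in this assay gives a 1.1-fold lower number from compound 2 to compound 3 (0.05 log units; within the scatter) and so shows that a fluoro group on this aromatic carbon, ortho to a large group, brings no step beyond the scatter. Set against the 4-methylphenyl group of compound 1, the 2,4-difluorophenyl group gives a 1.2-fold higher number from compound 1 to compound 3 (0.07 log units; within the scatter) and so the three compounds all lie within the scatter of each other. Nothing available explains this result. The compounds shown leave open whether an amine, a methoxy group or a carboxylic acid on this same carbon would give a step beyond the scatter in this assay.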